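Ethyl for allyl on the amino nitrogen of two cores

The compounds below may be only part of what the source reports. "The series", "measured", "known", "first", "only" and "open" are said of these compounds alone.

Measured so far, in a functional assay on CCRF-CEM cells (Homo sapiens) for cytotoxicity, read by resazurin assay, with a stated time of 48 h; on this read-out higher numbers stand for weaker inhibition and lower numbers for stronger inhibition:
compound 1 `CCN/C(SC)=C(/C#N)C(=O)Nc1ccc(OCC)cc1` gives 9890 nM
compound 2 `C=CCN/C(SC)=C(/C#N)C(=O)Nc1ccc(OCC)cc1` gives 18500 nM
compound 3 `C=CCNc1[nH]nc(N)c1C(=O)Nc1ccc(OCC)cc1` gives 6560 nM

Compound 1 and compound 2 share a core; the change between them is methyl in place of vinyl on a saturated chain carbon bound to an amine nitrogen and gave a 1.9-fold lower number from compound 2 to compound 1 (0.27 log units; within the scatter). Compound 3 has a different core, and the difference between the two cores is not broken down here; its value in this assay and that of compound 1 lie within the scatter of each other.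

Compound 4 `CCNc1[nH]nc(N)c1C(=O)Nc1ccc(OCC)cc1` is not yet measured. It differs from compound 3 by methyl in place of vinyl on a saturated chain carbon bound to a nitrogen on an aromatic ring. The surroundings are not the same word for word: in compound 2 and compound 1 the carbon is bound to an amine nitrogen, in compound 3 and compound 4 to a nitrogen on an aromatic ring, so this is the same kind of change, not the same change.

The step from compound 3 to compound 4 in this assay is expected to be small, about a 1.5-fold lower number from compound 3 to compound 4 (0.16 log units; within the scatter), resting on the earlier 1.9-fold lower number from compound 2 to compound 1 (0.27 log units; within the scatter) in compound 1. For compound 4 the estimate is 4500 nM, with a range from 2000 nM to 12000 nM.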

Compound 4, half-maximal inhibitory concentration: 14000 nM
Estimate against measurement, compound 4: 3.1-fold (0.49 log units) below; the whole stated range lies below it.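

On the core of compound 3, allyl to ethyl gives a 2.1-fold higher number from compound 3 to compound 4 (0.33 log units; beyond the scatter). Set beside the other core, the same change does not carry over in this assay: the same change on two cores in this assay, a 1.9-fold lower number (0.27 log units; within the scatter) from compound 2 to compound 1 and a 2.1-fold higher number (0.33 log units; beyond the scatter) from compound 3 to compound 4, 4.0-fold (0.60 log units) apart, beyond the scatter of two such steps. This shows that the step on the core of compound 1 was a poor guide to the step on the core of compound 3, but with one pair per core it neither establishes a general reversal between the cores nor gives a reason for the gap.

Open, going by these compounds, is how a longer chain such as propyl, or a hydroxyethyl group, on the same nitrogen would behave on each core. Also open, on these data alone, is whether other changes at this nitrogen would differ between the cores in the same way.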